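Removing One Hydroxy from Compound 3

The source may report more compounds than this note shows. Statements on the series, on what has been measured and on what is new or still open speak of the compounds shown alone.

Values in a functional assay, with a stated time of 30 min; a higher number here means a weaker inhibitor, a lower number a stronger inhibitor
- compound 1 `O=C(/C=C/c1ccc(O)cc1)CC(=O)/C=C/c1cccc(O)c1O` gives 27000 nM
- compound 2 `O=C(/C=C/c1ccc(O)c(O)c1)CC(=O)/C=C/c1cc(O)ccc1O` gives 60000 nM
- compound 3 `O=C(/C=C/c1cc(O)ccc1O)CC(=O)/C=C/c1cccc(O)c1O` gives 27000 nM

Compound 3 (27000 nM) stands level with compound 1, and the two share the lowest of the three numbers. Compound 4 `O=C(/C=C/c1cccc(O)c1)CC(=O)/C=C/c1cc(O)ccc1O` turns the 2,3-dihydroxyphenyl of compound 3 into 3-hydroxyphenyl, with hydrogen in place of hydroxy on an aromatic carbon. For the measured compounds named here, two measured steps bear on this. Changing one aryl group to 2,5-dihydroxyphenyl gave no change at the digits printed from compound 1 to compound 3 (within the scatter), and arriving at 2,3-dihydroxyphenyl gave a modest drop (a 2.2-fold lower number from compound 2 to compound 3 (0.35 log units; beyond the scatter)). Neither step removes this hydroxy alone, so only a small rise in the number is expected in this assay (a 1.5-fold higher number from compound 3 to compound 4 (0.17 log units; within the scatter)). For compound 4 the estimated value is 40000 nM (range 18000 nM to 90000 nM).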

Compound 4, half-maximal inhibitory concentration: 88000 nM
Estimate against measurement, compound 4: 2.2-fold (0.34 log units) below, and the stated range covers the measured number.
By their numbers in this assay, from the lowest: compounds 1 and 3 (each within the scatter of the next); then compounds 2 and 4 (each within the scatter of the next).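

In this assay, going from 2,3-dihydroxyphenyl to 3-hydroxyphenyl gives a 3.3-fold higher number from compound 3 to compound 4 (0.51 log units; beyond the scatter) and so shows that this hydroxy on the aromatic carbon carries a measurable, if modest, part of the activity of compound 3. The same kind of swap, hydrogen in place of hydroxy, on the same aryl group starting from the other dihydroxy pattern gives a 1.5-fold higher number from compound 2 to compound 4 (0.17 log units; within the scatter) and does not register, so which hydroxy is lost matters. No measurement shown here explains this difference.

As far as these compounds go, whether a methoxy or an amine at this position could keep the number of compound 3 remains open.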